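Mirror Image of a Potent Sigma-1 Ligand

The source may hold more compounds than are shown below. What is called first, only, known or untested is meant among the compounds shown, and "the series" means these compounds.

Compound 1 `c1ccc([C@@H]2CCC[C@H](CCNCC3CCCCC3)O2)cc1` is the stronger of two measured compounds in an assay on membranes from brain for displacement of a labelled ligand from Sigma non-opioid intracellular receptor 1 (Cavia porcellus), read by scintillation counting, with a stated time of 120 min (on this read-out lower numbers stand for stronger inhibition and higher numbers for weaker inhibition), where compound 1 gives 2.4 nM. Compound 2 `CN(C)CC[C@H]1CCC[C@@H](c2ccccc2)O1`, which carries a shorter amine-bearing chain on the same core, gives 217 nM in this assay, a number beyond the scatter above that of compound 1. Compound 3 `c1ccc([C@H]2CCC[C@@H](CCNCC3CCCCC3)O2)cc1` is the mirror image of compound 1: the two compounds have the same atoms and bonds and differ only in configuration as drawn: 2 of 2 stereo elements differ (all stereocentres are inverted: mirror images); a stereocentre at a saturated ring carbon is drawn S in compound 1 and R in compound 3; a stereocentre at a saturated ring carbon is drawn R in compound 1 and S in compound 3. Among the compounds with values here, no pair of measured compounds differs in a single place, so no measured step shows how this assay responds to inversion of configuration. On the data at hand, compound 3 is expected to bind somewhat less strongly than compound 1, with a step of a 3.3-fold higher number from compound 1 to compound 3 (0.52 log units; beyond the scatter) that may or may not exceed the scatter. The estimate for compound 3 in this assay is 8 nM, within a range from 1.5 nM to 50 nM.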

Compound 3, inhibition constant: 0.95 nM
Compound 3: middle estimate off by 8.4-fold (0.93 log units), on the high side; measured number below the stated range.
By their numbers in this assay, from the lowest: compound 3; then compound 1; then compound 2.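

Inverting both stereocentres of compound 1 does not weaken binding in this assay; instead, the change gives a 2.5-fold lower number from compound 1 to compound 3 (0.40 log units; beyond the scatter). The earlier compounds shown here gave no view of configuration at these two positions, and this pair shows that the assay distinguishes the mirror images, though only modestly, with both remaining strong binders. The step can be assigned to configuration alone: the fact that compounds 1 and 3 differ only in the configuration as drawn

The compounds shown leave open how much each stereocentre contributes alone, as the two invert together in this pair. They also leave open whether compound 3 would keep its edge over its mirror image if the cyclohexylmethyl group on the amine gave way to a benzyl group, or if the phenyl ring carried a fluorine.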